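The source may hold more compounds than are shown below. What is called first, only, known or untested is meant among the compounds shown, and "the series" means these compounds.

Compound 1 `Cc1ccc(S(=O)(=O)NCCCNc2nccc(-c3c(-c4cccc(F)c4)nc4sccn34)n2)cc1`, compound 2 `O=C(NCCCNc1nccc(-c2c(-c3cccc(F)c3)nc3sccn23)n1)c1ccc(F)cc1`, compound 3 `O=S(=O)(NCCCNc1nccc(-c2c(-c3cccc(F)c3)nc3sccn23)n1)c1ccc(C(F)(F)F)cc1` and the not yet measured compound 4 `O=S(=O)(NCCCNc1nccc(-c2c(-c3cccc(F)c3)nc3sccn23)n1)c1cccc(F)c1` share one core and differ only in the group on an amine nitrogen of the chain. In a functional assay on SK-MEL-28 cells (Homo sapiens) for cytotoxicity, read by MTT assay (on this read-out higher numbers stand for weaker inhibition and lower numbers for stronger inhibition), compound 1 gives 9500 nM and compound 3 gives 11700 nM. For compound 2, this assay reports only a limit, > 20000 nM. Compound 2 thus stands at the weak end of what is shown, at the limit of > 20000 nM in this assay, at which 1 of the 3 values shown sits. Going from compound 2 to compound 4, ((3-fluorophenyl)sulfonyl in place of (4-fluorophenyl)carbonyl on an amine nitrogen). Among the compounds with values here, two measured steps bear on this: an at least 2.1-fold higher number from compound 1 to compound 2 (0.32 log units; beyond the scatter), and a 1.2-fold higher number from compound 1 to compound 3 (0.09 log units; within the scatter). Because an at least 2.1-fold higher number from compound 1 to compound 2 (0.32 log units; beyond the scatter) went against the carbonyl, the number for compound 4 is expected to come back down, with the change in the fluorine-bearing ring expected to matter little. For compound 4 the expected step is an at least 1.8-fold lower number from compound 2 to compound 4 (0.25 log units; that floor lies within the scatter). Compound 4 is therefore estimated at 11000 nM, within a range from 5000 nM to 25000 nM.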

Compound 4, half-maximal inhibitory concentration: 8550 nM
Compound 4: middle estimate off by 1.3-fold (0.11 log units), on the high side, within the range that was stated.
By their numbers in this assay, from the lowest: compounds 4, 1 and 3 (each within the scatter of the next). At a limit, above all of these: compound 2.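

In this assay, an at least 2.3-fold lower number from compound 2 to compound 4 (0.36 log units; beyond the scatter), which sets a third sulfonyl compound clear of the carbonyl compound, although compound 2 has only a limit: the limit of > 20000 nM in this assay, at which 1 of the 4 values shown sits. The aryl group on the sulfonyl sulfur can also change with no shift beyond the scatter: a 1.4-fold lower number from compound 3 to compound 4 (0.14 log units; within the scatter), and a 1.1-fold lower number from compound 1 to compound 4 (0.05 log units; within the scatter).

From the compounds shown here alone, the step from compound 2 to compound 4 changes both the carbonyl and the place of the fluorine, so how much each one counts stays open. Also open, going by these compounds, is whether an amine or carboxylic acid on that aromatic ring, or a longer chain, would move the number beyond the scatter.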